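Chloro in Place of Trifluoromethyl on Compound 2

The source may hold more compounds than are shown below. What is called first, only, known or untested is meant among the compounds shown, and "the series" means these compounds.

Compound 1, `C[C@@H](NC(=O)Nc1cccc(C(F)(F)F)c1)c1ccccc1`, in an ADME assay on the whole organism with Oryza sativa as the target, tested at 10 uM (on this read-out higher numbers stand for a weaker effect at the one concentration tested and lower numbers for a stronger effect), gives 70%.
Compound 2, `C[C@H](NC(=O)Nc1cccc(C(F)(F)F)c1)c1ccccc1`, in this assay gives 92%.
Compound 3, `CC(=O)c1ccc(NC(=O)N[C@H](C)c2ccccc2)cc1`, in this assay gives 84%.

Compound 2 gives the highest of the three numbers. Compound 3 lies within the usual scatter of it, so the two cannot be told apart on this read-out. Compound 1 lies further off: a number 22 percentage points higher from compound 1 to compound 2 (beyond the scatter). The only thing separating these two compounds is the fact that compounds 1 and 2 differ only in the configuration as drawn, so this single measured step speaks of configuration and of nothing else.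

Compound 4, `C[C@H](NC(=O)Nc1cccc(Cl)c1)c1ccccc1`, differs from compound 2 in one place: chloro in place of trifluoromethyl on an aromatic carbon. Among the measured compounds shown here, no measured step in this assay touches an exchange of this kind; the one step that was measured concerns configuration alone and offers no guide to swapping one group for another on the aromatic ring. The two groups are both small and uncharged, with no hydrogen-bond donors or acceptors entering or leaving. On this basis the expected step in this assay is a number 5 percentage points lower from compound 2 to compound 4 (within the scatter), that is, none beyond the usual scatter. For compound 4 in this assay the estimate is 87%, with a range from 67% to 100%.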

Compound 4, a percentage reported as activity, at one concentration (the size of the read-out at that concentration, not a potency): 103%
Estimate against measurement, compound 4: 16 percentage points below; measured number above the stated range.
By their numbers in this assay, from the lowest: compound 1; then compounds 3 and 2 (each within the scatter of the next); then compound 4.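

In this assay, among the compounds shown here, the aromatic carbon meta to a large group proves sensitive to which group it carries, which the earlier compounds could not show, since their one measured step concerned configuration alone: a number 11 percentage points higher from compound 2 to compound 4 (beyond the scatter). The step is modest but beyond the scatter, and it runs towards a weaker effect at the one concentration tested, so at this position chloro, with its single heavy atom, reads differently from trifluoromethyl, with four, while neither group brings a hydrogen-bond donor or acceptor or a net charge. Nothing at hand accounts for this step, as the only supporting observation concerns configuration and does not touch the exchange of one group for another on the aromatic ring.

Among the compounds shown, chloro stands only with the configuration drawn in compound 2, so it remains open whether the same exchange would move the number in the same direction with the configuration drawn in compound 1. Also open, from the compounds shown here alone, is how this position would read with a methoxy group, an amine or a carboxylic acid, each of which differs from both chloro and trifluoromethyl in its atoms.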